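Dropping the allyl group: what the free phenol might do

The source may report more compounds than this note shows. Statements on the series, on what has been measured and on what is new or still open speak of the compounds shown alone.

Compound 1 `C=CCOc1cc(Br)ccc1C(=O)c1cccnc1` sits at the ceiling of a functional assay on MCF7 cells (Homo sapiens) for cytotoxicity, read by sulforhodamine B assay, with a stated time of 48 h; on this read-out lower numbers stand for stronger inhibition and higher numbers for weaker inhibition: in this assay compound 1 gives > 100000 nM, a limit rather than a number. Compound 2 `C=CCOc1c(Cl)cccc1C(=O)c1cccnc1` likewise returns only a limit, > 100000 nM. Within the data shown here, in short, (the limit of > 100000 nM in this assay, at which 2 of the 2 values shown sit), so no measured step is available. Compound 3 `O=C(c1cccnc1)c1ccc(Br)cc1O` differs from compound 1 by hydrogen in place of allyl on an oxygen on an aromatic ring. With both known values at the limit, the author expects the step of an at least 1.2-fold lower number from compound 1 to compound 3 (0.09 log units; that floor lies within the scatter) to be modest, leaning if anything towards stronger inhibition. Compound 3 is therefore estimated at 80000 nM, within a range from 20000 nM to 200000 nM, with a fair chance that the assay again reports only a limit.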

Compound 3, half-maximal inhibitory concentration: > 100000 nM
Compound 3: no number, only a limit (the forecaster's own chance of this, stated with the estimate: 55%); at least 1.2-fold (0.09 log units) between middle value and limit.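

Compound 1 and compound 3 both return only a limit, so the change from allyloxy to hydroxy gives no readable step: the limit of > 100000 nM in this assay, at which 3 of the 3 values shown sit. The compounds shown leave open whether any change to the shared core gives a measurable number in this assay at all.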